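This account rests on a few compounds, and the source may have more. Where it says the series, first, only, none or still open, it means among the compounds named here.

Of the compounds shown here, two built on one shared core have been tested in a functional assay on HT-29 cells (Homo sapiens) for cytotoxicity, read by sulforhodamine B assay; on this read-out higher numbers stand for weaker inhibition of growth and lower numbers for stronger inhibition of growth. Compound 1 `CC1=CC[C@@H]([C@@](C)(O)CCCC(C)(C)NC(=S)N/N=C\c2ccc(O)cc2)CC1` gives 8150 nM. Compound 2 `CC1=CC[C@@H]([C@@](C)(O)CCCC(C)(C)NC(=S)N/N=C\c2ccccc2[N+](=O)[O-])CC1` gives 6940 nM. Going by the values given here, the only measured step, a 1.2-fold lower number from compound 1 to compound 2 (0.07 log units; within the scatter), changed a group on the aromatic ring attached to the carbon with the double bond to nitrogen and moved the number by less than the scatter. Compound 2 therefore holds the smaller of the two numbers shown, but the gap to compound 1 is within the scatter, so nothing separates the two on this read-out. Compound 3 `CC1=CC[C@@H]([C@@](C)(O)CCCC(C)(C)NC(=S)N/N=C\c2ccccc2Cl)CC1` differs from compound 2 by chloro in place of nitro on an aromatic carbon. Among the compounds with values here, the one step that bears on this change is the swap on the same aromatic ring between compound 1 and compound 2, which produced no shift beyond the scatter. The step of a 1.0-fold higher number from compound 2 to compound 3 (0.00 log units; within the scatter) is thus expected to stay within the scatter, in no particular direction. Compound 3 is estimated at 7000 nM in this assay, with a range from 3000 nM to 16000 nM.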

Compound 3, concentration for 50% growth inhibition: 23700 nM
Compound 3: middle estimate off by 3.4-fold (0.53 log units), on the low side; measured number outside the range, above it.
By their numbers in this assay, from the lowest: compounds 2 and 1 (each within the scatter of the next); then compound 3.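

In this assay the group at this place on the aromatic ring is not indifferent: chloro in place of nitro gives a 3.4-fold higher number from compound 2 to compound 3 (0.53 log units; beyond the scatter), a move towards weaker inhibition of growth. The 2-chlorophenyl compound also separates from the 4-hydroxyphenyl compound, with a 2.9-fold higher number from compound 1 to compound 3 (0.46 log units; beyond the scatter), so compound 3 stands apart from two compounds that could not be told apart from each other. Nothing available gives a reason for this rise.

As far as these compounds go, with only nitro and chloro compared at this place, it stays open whether the higher number is particular to chloro or would appear with other groups there. Whether an amine, a methoxy group or a fluoro group at the same aromatic carbon would sit with compound 2 or with compound 3 cannot be told from these three compounds.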